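The source may report more compounds than this note shows. Statements on the series, on what has been measured and on what is new or still open speak of the compounds shown alone.

Compound 1 `CCc1ccc(SCc2ccc(C(=O)Nc3ccccc3N)cc2)cc1`: 40.7%
Compound 2 `CC(C)(C)c1ccc(SCc2ccc(C(=O)Nc3ccccc3N)cc2)cc1`: 4.81%

In a functional assay on HCT-116 cells (Homo sapiens) for inhibition, read by CCK-8 assay, with a stated time of 72 h, tested at 2 uM (on this read-out lower numbers stand for less inhibition of growth and higher numbers for more inhibition of growth at the one concentration tested), compound 2 stands lowest of the two measured compounds, at 4.81%. The next compound, compound 3 `Nc1ccccc1NC(=O)c1ccc(CSc2ccc(F)cc2)cc1`, changes that same compound at one place: fluoro in place of tert-butyl on an aromatic carbon. In words, this is fluoro in place of tert-butyl on an aromatic carbon, para to a large group. Within the data shown here, one measured step bears on it: a number 35.9 percentage points lower from compound 1 to compound 2 (beyond the scatter), a large change with tert-butyl in place of ethyl on an aromatic carbon. Among the measured compounds shown here, compound 3 also gives up the tert-butyl, so a rise towards compound 1 at 40.7% is expected, although no measurement yet shows how fluoro behaves here. The expected change is a number 28.2 percentage points higher from compound 2 to compound 3 (beyond the scatter), an upward step likely to lie beyond the scatter. For compound 3 the estimated value is 33%, with an expected range of 10% to 60%.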

Compound 3, percent growth inhibition at one concentration: 13.5%
Beside the measured number, compound 3's estimate is 19.5 percentage points above it, within the range that was stated.
By their numbers in this assay, from the lowest: compounds 2 and 3 (each within the scatter of the next); then compound 1.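

In this assay, fluoro in place of tert-butyl gives a number 8.7 percentage points higher from compound 2 to compound 3 (within the scatter) and so does not separate these two groups at this position on the aromatic ring. Fluoro in place of ethyl gives a number 27.2 percentage points lower from compound 1 to compound 3 (beyond the scatter) and shows that the lower numbers are not tied to tert-butyl alone, as compound 2 by itself might have suggested, since ethyl now stands apart from both other groups. Nothing measured here speaks to the reason for this pattern.

The compounds shown leave open whether the level of compound 1 belongs to ethyl alone or would also be reached with a methyl, a longer chain such as propyl, or a methoxy at this place. They also leave open whether compound 1 would stay apart from compound 3 at other concentrations.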